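A formyl group in place of methyl

The source may hold more compounds than are shown below. What is called first, only, known or untested is meant among the compounds shown, and "the series" means these compounds.

In a functional assay on MV4-11 cells (Homo sapiens) for inhibition, read by resazurin assay, with a stated time of 72 h (on this read-out lower numbers stand for stronger inhibition of growth and higher numbers for weaker inhibition of growth), compound 1 (`O=Cc1ccc(-c2cncc(Cl)c2N2CCC3(CCNC3=O)CC2)o1`) gives 5190 nM on the shared core. Compound 2 (`Cc1ccc(-c2cncc(Cl)c2N2CCC3(CCNC3=O)CC2)s1`) gives 650 nM and so holds the lower of the two numbers. Within the data shown here, the one measured step is an 8.0-fold lower number from compound 1 to compound 2 (0.90 log units; beyond the scatter) and it bears on what follows, though it puts 5-methylthiophen-2-yl in place of 5-formylfuran-2-yl and so changes the ring and its substituent together.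

Compound 3 (`O=Cc1ccc(-c2cncc(Cl)c2N2CCC3(CCNC3=O)CC2)s1`) has not been measured. It differs from compound 2 by formyl in place of methyl on an aromatic carbon next to the ring sulfur. Compound 3 keeps the ring of compound 2, which gives 650 nM here, and takes up the formyl of compound 1, which gives 5190 nM here. The data do not show how the measured step divides between the two changes. A move toward the higher number is expected, covering part of the measured step but not all of it. The estimated change is a 2.8-fold higher number from compound 2 to compound 3 (0.44 log units; beyond the scatter) as the expected size in this assay for this pair. For compound 3 the estimate is 1800 nM with an expected range from 600 nM to 5000 nM in all.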

Compound 3, concentration for 50% growth inhibition: 750 nM
For compound 3 the middle estimate is 2.4-fold (0.38 log units) above the measured one; low and high end bracket the measured number.
By their numbers in this assay, from the lowest: compounds 2 and 3 (each within the scatter of the next); then compound 1.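

On the aromatic carbon next to the ring sulfur, the change from methyl to formyl gives a 1.2-fold higher number from compound 2 to compound 3 (0.06 log units; within the scatter) in this assay, so with the sulfur-containing ring in place, this assay does not separate the two groups. The earlier step from compound 1 to compound 2 changed the ring and its substituent together, but with formyl held constant, the ring change alone gives a 6.9-fold lower number from compound 1 to compound 3 (0.84 log units; beyond the scatter), which places compound 3 within the scatter of compound 2 and shows that formyl itself does not carry compound 1 to its higher number. Nothing measured here explains why the two groups read alike on this ring or why the ring change matters.

The compounds shown leave open whether a 5-methylfuran-2-yl group would also read like the 5-formylfuran-2-yl group of compound 1, which would test whether methyl and formyl are equally interchangeable on the oxygen-containing ring. They also leave open how far this tolerance extends on the sulfur-containing ring, since a carboxylic acid, an aminomethyl group or a longer alkyl chain at the same carbon could read quite differently from methyl and formyl.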